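Carbamate alkynes: ester length and terminal ring

The compounds below may be only part of what the source reports. "The series", "measured", "known", "first", "only" and "open" are said of these compounds alone.

Measured so far in a functional assay on the whole organism for agonist activity, with Mus musculus as the target; a lower number here means that less compound is needed, a higher number that more compound is needed for the effect:
compound 1 `COC(=O)N(C)CC#CCN1CCCC1` gives 5.5 mg/kg.
compound 2 `COC(=O)N(C)CC#CCn1ccnc1` gives 4.5 mg/kg.
compound 3 `CCOC(=O)N(C)CC#CCN1CCCC1` gives only a limit, > 100 mg/kg.

Compound 1 and compound 2 share the core of compound 1 and differ by 1H-imidazol-1-yl in place of pyrrolidin-1-yl on a saturated chain carbon bound to a triple-bonded carbon. That step is a 1.2-fold lower number from compound 1 to compound 2 (0.09 log units; within the scatter). Compound 3 differs from compound 1 by methyl in place of hydrogen on a saturated chain carbon bound to an oxygen next to a carbonyl group, and that step is an at least 18-fold higher number from compound 1 to compound 3 (1.25 log units; beyond the scatter). For compound 3 this assay reports a limit, (the limit of > 100 mg/kg in this assay, at which 1 of the 3 values shown sits), and not a number.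

Compound 4 `CCOC(=O)N(C)CC#CCn1ccnc1` has not yet been measured in this assay. It differs from compound 3 by 1H-imidazol-1-yl in place of pyrrolidin-1-yl on a saturated chain carbon bound to a triple-bonded carbon, the same change as that from compound 1 to compound 2. Because that change gave a 1.2-fold lower number from compound 1 to compound 2 (0.09 log units; within the scatter) on the methoxycarbonyl pair, the step from compound 3 to compound 4 is expected to be a step that the limit leaves unreadable from compound 3 to compound 4. Compound 4 is therefore expected to give 150 mg/kg in this assay, most likely reported again as a limit, with the estimate spanning 40 mg/kg to 600 mg/kg.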

Compound 4, dose for half-maximal effect: > 100 mg/kg
Compound 4 gave a limit, no number; the forecaster's own chance of this, stated with the estimate: 80%; the middle value does not contradict the limit.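

In this assay, methyl in place of hydrogen on a saturated chain carbon bound to an oxygen next to a carbonyl group gives an at least 22-fold higher number from compound 2 to compound 4 (1.34 log units; beyond the scatter), so the change goes the same way and is large on both the pyrrolidin-1-yl and the 1H-imidazol-1-yl cores. Set side by side, the two steps cannot be told apart in size: the same change on two cores in this assay, an at least 18-fold higher number (1.25 log units; beyond the scatter) from compound 1 to compound 3 and an at least 22-fold higher number (1.34 log units; beyond the scatter) from compound 2 to compound 4; the limit leaves it open whether they differ

The step between compound 3 and compound 4 cannot be read, and it stays unknown whether 1H-imidazol-1-yl in place of pyrrolidin-1-yl behaves on this ester as it does on the core of compound 1, with both compounds reported only as a limit: the limit of > 100 mg/kg in this assay, at which 2 of the 4 values shown sit.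

The compounds shown leave open how far beyond the limit compound 3 and compound 4 truly lie. They also leave open how a longer chain on the ester oxygen, such as propyl, or a different terminal amine, such as piperidin-1-yl or dimethylamino, would read in this assay.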